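A few compounds are considered here, and "the series" means these few. Any claim that something is new, unique, unknown or untested is made for them only; others in the source may bear on it.

Measured compounds:
Compound 1, `O=C(NC1CC1)c1cc(Oc2cccc(NC(=S)Nc3cccc(C(F)(F)F)c3)c2)ccn1` — in a functional assay on HCT-116 cells (Homo sapiens) for cytotoxicity, read by MTT assay, with a stated time of 48 h (on this read-out higher numbers stand for weaker inhibition and lower numbers for stronger inhibition), compound 1 gives 20200 nM.
Compound 2, `O=C(c1cc(Oc2cccc(NC(=S)Nc3cccc(C(F)(F)F)c3)c2)ccn1)N1CCCC1` — in this assay compound 2 gives 19200 nM.

Compound 2 holds the lower of the two numbers, yet its gap to compound 1 is small: a 1.1-fold lower number from compound 1 to compound 2 (0.02 log units; within the scatter), a change confined to the carbonyl substituent and within the scatter. Compound 3, `O=C(c1cc(Oc2cccc(NC(=S)Nc3ccc(OC(F)(F)F)cc3)c2)ccn1)N1CCCC1`, takes a different route. It keeps the pyrrolidinyl amide of compound 2 and alters the aryl on the thiourea instead: 4-(trifluoromethoxy)phenyl in place of 3-(trifluoromethyl)phenyl on an amide-type nitrogen. Going by the values given here, no measured step touches this part of the molecule; the one step known concerns the amide only and was flat. There is therefore no basis for expecting movement beyond the scatter, in either direction. Compound 3 is accordingly expected to give about 19000 nM in this assay, with a range from 6000 nM to 55000 nM, which amounts to an expected 1.0-fold lower number from compound 2 to compound 3 (0.00 log units; within the scatter).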

Compound 3, half-maximal inhibitory concentration: 17800 nM
Compound 3: middle estimate off by 1.1-fold (0.03 log units), on the high side; the measured number falls inside the stated range.
By their numbers in this assay, from the lowest: compounds 3, 2 and 1 (each within the scatter of the next).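

Going by these compounds alone, the aryl on the thiourea had not been varied among the earlier compounds, and in this assay exchanging 3-(trifluoromethyl)phenyl for 4-(trifluoromethoxy)phenyl on this amide-type nitrogen gives a 1.1-fold lower number from compound 2 to compound 3 (0.03 log units; within the scatter), so this position, like the carbonyl substituent, shows no step beyond the scatter so far. The exchange alters both the group and its numbered place on the ring, and the entering group counts one hydrogen-bond acceptor where the leaving group counts none, so the result cannot separate these differences. (No supporting evidence is available to explain the result)

As far as these compounds go, it remains open whether an aryl carrying a carboxylic acid or an amine would move the value beyond the scatter at this position. From the compounds shown here alone, the effect of a urea in place of the thiourea also remains open.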